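This account rests on a few compounds, and the source may have more. Where it says the series, first, only, none or still open, it means among the compounds named here.

Compounds measured so far:
compound 1 `CCN(CC)c1ccc2cc(C(=O)c3ccc(N4CCN(S(=O)(=O)c5ccc([N+](=O)[O-])cc5)CC4)cc3)oc2c1` gives 24400 nM in a functional assay on A549 cells (Homo sapiens) for cytotoxicity, read by MTT assay, with a stated time of 48 h; on this read-out lower numbers stand for stronger inhibition and higher numbers for weaker inhibition
compound 2 `CCN(CC)c1ccc2cc(C(=O)c3ccc(N4CCN(S(=O)(=O)c5ccc(F)cc5)CC4)cc3)oc2c1` gives 16400 nM in this assay

Among the measured compounds shown here, compound 2 has the lower of the two numbers, yet the only measured step, a 1.5-fold lower number from compound 1 to compound 2 (0.17 log units; within the scatter), stays within the scatter, so the two compounds cannot be told apart. Compound 3 `CCN(CC)c1ccc2cc(C(=O)c3ccc(N4CCN(C(C)=O)CC4)cc3)oc2c1` differs from compound 2 by acetyl in place of (4-fluorophenyl)sulfonyl on an amine nitrogen in a ring. For the measured compounds named here, that single measured step altered only a substituent on the aromatic ring; no measured pair covers exchanging the whole sulfonyl group for acetyl, so it guides little. With nothing pointing either way, compound 3 is expected near compound 2, at an estimated 25000 nM with a range from 8000 nM to 80000 nM. The expected step is a 1.5-fold higher number from compound 2 to compound 3 (0.18 log units; within the scatter).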

Compound 3, half-maximal inhibitory concentration: 30100 nM
Compound 3: the middle estimate sits 1.2-fold (0.08 log units) below what was measured; the range from low to high includes it.
By their numbers in this assay, from the lowest: compounds 2, 1 and 3 (each within the scatter of the next).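

Exchanging a whole (4-fluorophenyl)sulfonyl or (4-nitrophenyl)sulfonyl group for acetyl on this amine nitrogen, which also removes an aromatic ring, leaves the result in this assay within the scatter (a 1.8-fold higher number from compound 2 to compound 3 (0.26 log units; within the scatter); a 1.2-fold higher number from compound 1 to compound 3 (0.09 log units; within the scatter)). This position therefore tolerates a far larger replacement than the earlier aromatic substituent swap, with no measurable difference among the three compounds. No supporting measurement explains this.

On these data alone, it remains open whether a benzyl group, a longer alkyl chain or a carboxylic acid on this nitrogen would move the number beyond the scatter.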